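Phenylsulfonyl analogue of compound 1: expected inhibition

This account rests on a few compounds, and the source may have more. Where it says the series, first, only, none or still open, it means among the compounds named here.

Measured so far:
compound 1 `CC(O)(CS(=O)(=O)c1ccc(F)cc1)c1cn(-c2ccc(C#N)c(C(F)(F)F)c2)nn1`: 45000 nM in a functional assay on LNCaP cells (Homo sapiens) for inhibition; on this read-out lower numbers stand for stronger inhibition and higher numbers for weaker inhibition
compound 2 `CC(O)(CS(=O)(=O)c1ccc(F)cc1)c1cn(-c2ccc([N+](=O)[O-])c(C(F)(F)F)c2)nn1`: 36000 nM in this assay

Among the compounds with values here, compound 1 stands highest of the two numbers; its nearest neighbour is compound 2, and the only measured step, a 1.3-fold lower number from compound 1 to compound 2 (0.10 log units; within the scatter), nitro in place of cyano on an aromatic carbon, lies within the scatter. Compound 3 `CC(O)(CS(=O)(=O)c1ccccc1)c1cn(-c2ccc(C#N)c(C(F)(F)F)c2)nn1` differs from compound 1 by hydrogen in place of fluoro on an aromatic carbon, read one bond further out as (4-fluorophenyl)sulfonyl to phenylsulfonyl. Within the data shown here, no measured step touches this part of the structure, so nothing points in either direction. For compound 3 the expected step is no change at the digits printed from compound 1 to compound 3 (within the scatter), none beyond the scatter. Compound 3 is therefore estimated at 45000 nM, in the range 15000 nM to 135000 nM.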

Compound 3, half-maximal inhibitory concentration: 151000 nM
Compound 3: the middle estimate sits 3.4-fold (0.53 log units) below what was measured; the measured number lies above the stated range.
By their numbers in this assay, from the lowest: compounds 2 and 1 (each within the scatter of the next); then compound 3.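

In this assay the aromatic carbon carrying fluoro proves responsive: the change shows a 3.4-fold higher number from compound 1 to compound 3 (0.53 log units; beyond the scatter) with hydrogen in place of fluoro, so inhibition weakens when fluoro leaves. Within the data shown here, the earlier nitro for cyano exchange, made elsewhere in the structure, stayed within the scatter, so this is the first change to go beyond it. No supporting measurement bears on why this change matters.

Still open, from the compounds shown here alone, is whether chloro, methoxy or an amine at this place would match fluoro. Also open, going by these compounds, is whether removing fluoro from compound 2 costs as much.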